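Methoxy in place of (ethylsulfonyl)amino on the shared core

The compounds below may be only part of what the source reports. "The series", "measured", "known", "first", "only" and "open" are said of these compounds alone.

Compound 1 `CCS(=O)(=O)Nc1cccc2c1CCC2c1ncc[nH]1` is the anchor of this comparison. In a functional assay on CHO cells for agonist activity at Alpha-1B adrenergic receptor (Homo sapiens), read by FLIPR and calcium flux (on this read-out lower numbers stand for an effect already at smaller amounts and higher numbers for an effect only at larger amounts of compound), compound 1 gives > 10000 nM, which is a limit of the assay and not a number. Compound 2 `CS(=O)(=O)Nc1c(Cl)ccc2c1CCCC2c1ncc[nH]1` gives > 10000 nM in this assay, also a limit. Compound 3 `c1cncc(-c2cccc3c2CCC3c2ncc[nH]2)c1` gives > 10000 nM in this assay, again a limit. Hence the limit of > 10000 nM in this assay, at which 3 of the 3 values shown sit: compound 1 stands at the same limit as the other two, and nothing in the numbers ranks it. Within the data shown here, the only single-site step available, a step that the two limits leave unreadable from compound 1 to compound 3, cannot be read for size.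

Compound 4 `COc1cccc2c1CCC2c1ncc[nH]1` differs from compound 1 by methoxy in place of (ethylsulfonyl)amino on an aromatic carbon. Among the measured compounds shown here, no measured step involves a methoxy, and the one step from compound 1 is unreadable, so no measured step bears directly on this change; three values at the limit give neither size nor direction. The expectation for the step in this assay is therefore none beyond the scatter, with compound 4 most likely again at the limit. Compound 4 is estimated at 20000 nM in this assay, with a range from 4000 nM to 100000 nM. The implied step is expected to be a step that the limit leaves unreadable from compound 1 to compound 4.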

Compound 4, half-maximal effective concentration: > 10000 nM
Compound 4 gave a limit, no number (the forecaster's own chance of this, stated with the estimate: 75%); the middle value lies beyond the limit too.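

Compound 4 adds no readable step against compound 1 or compound 3, because each value in this assay is a limit and not a number: the limit of > 10000 nM in this assay, at which 4 of the 4 values shown sit.

The compounds shown leave open whether any group on the shared core gives a measurable effect in this assay and how these four compounds rank.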